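Turning One Double Bond from Z to E

A few compounds are considered here, and "the series" means these few. Any claim that something is new, unique, unknown or untested is made for them only; others in the source may bear on it.

- compound 1 `CN(C[C@H]1Cc2ncccc2CN1)[C@H]1CCCc2cccnc21` gives 1300 nm/s
- compound 2 `NC(=O)NC/C=C\CN(C[C@H]1Cc2ncccc2CN1)[C@H]1CCCc2cccnc21` gives 2 nm/s

These values come from an ADME assay for permeability, using PAMPA, with a stated time of 4 h, at pH 7.4; on this read-out higher numbers stand for higher permeability and lower numbers for lower permeability. Within the data shown here, compound 2 stands lowest of the two, and the only measured step is a 650-fold lower number from compound 1 to compound 2 (2.81 log units; beyond the scatter), a large one and beyond the scatter. Compound 3 `NC(=O)NC/C=C/CN(C[C@H]1Cc2ncccc2CN1)[C@H]1CCCc2cccnc21` is closely related to compound 2: the two compounds have the same atoms and bonds and differ only in configuration as drawn: 1 of 3 stereo elements differ; a double bond is drawn Z in compound 2 and E in compound 3. Among the measured compounds shown here, the measured step bears on this only indirectly, as the group it introduced remains in compound 3, and no measured pair tests the configuration of the double bond. With nothing to suggest a large shift, compound 3 is expected to stay close to compound 2 at 2 nm/s. The expected change is a 1.5-fold higher number from compound 2 to compound 3 (0.18 log units; within the scatter), which would not lie beyond the scatter. For compound 3 the estimated value is 3 nm/s, within an expected range of 1 nm/s to 15 nm/s.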

Compound 3, apparent permeability: 2 nm/s
Estimate against measurement, compound 3: 1.5-fold (0.18 log units) above; the range from low to high includes it.
By their numbers in this assay, from the lowest: compounds 2 and 3 (each within the scatter of the next); then compound 1.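

In this assay, the drawn geometry of the double bond does not separate the two forms, with no change at the digits printed from compound 2 to compound 3 (within the scatter). The E form carries the same large drop as the Z form, with a 650-fold lower number from compound 1 to compound 3 (2.81 log units; beyond the scatter), so at this position the low number goes with the added group of 7 heavy atoms in either configuration of the double bond. The comparison therefore speaks to one point alone: the fact that compounds 2 and 3 differ only in the configuration as drawn

The compounds shown leave open which part of the added group goes with the drop. A saturated butyl chain with the same terminal group, a plain alkyl chain, or a shorter chain ending in an amine or a carboxylic acid would each address that question, and the double bond's own contribution also stays unresolved.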